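A few compounds are considered here, and "the series" means these few. Any claim that something is new, unique, unknown or untested is made for them only; others in the source may bear on it.

The study looks at two measured nucleosides and one that has not yet been tested. Compound 1, `OCCNc1nccc2c1ncn2C1O[C@H](CO)[C@@H](O)[C@H]1O`, was tested in a functional assay (Homo sapiens) for inhibition of Nucleic Acid, tested at 100 uM (on this read-out lower numbers stand for less inhibition and higher numbers for more inhibition at the one concentration tested (going by the name of the read-out)), and compound 1 gives 0% there. Compound 2, `OC[C@H]1O[C@@H](n2cnc3c(Cl)nccc32)C[C@@H]1O`, gives 5% in this assay. Compound 1 stands at the low end of the two numbers shown, yet the gap to compound 2 lies within the usual scatter of such measurements, so the two compounds cannot be told apart on this read-out.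

Compound 3, `CCCCCCNc1nccc2c1ncn2C1O[C@H](CO)[C@@H](O)[C@H]1O`, differs from compound 1 in one place: butyl in place of hydroxy on a saturated chain carbon, two bonds along the chain from a nitrogen on an aromatic ring. Among the measured compounds shown here, no step between measured compounds speaks to a change of this kind, and both measured values sit near zero. The step from compound 1 to compound 3 is therefore expected to be small, a number 5 percentage points higher from compound 1 to compound 3 (within the scatter), not beyond the scatter in either direction. Compound 3 is estimated to give 5% in this assay, within a range from -5% to 25%.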

Compound 3, a percentage reported as inhibition, at one concentration (the size of the read-out at that concentration, not a potency): 8%
For compound 3 the middle estimate is 3 percentage points below the measured one, and the stated range covers the measured number.
By their numbers in this assay, from the lowest: compounds 1, 2 and 3 (each within the scatter of the next).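

Butyl in place of hydroxy on a saturated chain carbon, two bonds along the chain from a nitrogen on an aromatic ring, comes with a number 8 percentage points higher from compound 1 to compound 3 (within the scatter) in this assay. Among the compounds shown here, this is the first step that can be read at this position, and it shows that exchanging 2-hydroxyethyl for hexyl on the shared core leaves the read-out within the scatter at the one concentration tested, with all the numbers still close to zero. Nothing measured here accounts for this result.

The compounds shown leave open whether an amine or a carboxylic acid at the end of this chain, or a longer chain, would move the number beyond the scatter. They also leave open how the two groups would compare at higher inhibition, where a difference could be read.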